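Cytotoxicity of a Phenoxy Variant of Compound 2

The compounds below may be only part of what the source reports. "The series", "measured", "known", "first", "only" and "open" are said of these compounds alone.

Compound 2 `CCOC(=O)CCCCCOc1cccc(CN(C(=O)c2ccc(-c3cccc(-c4ccccc4)c3)cc2)C(C)C)c1` was tested in an ADME assay on HepG2 cells (Homo sapiens) for cytotoxicity, read by CellTiter-Glo and resazurin assay, with a stated time of 72 h; a lower number here means that less compound is needed, a higher number that more compound is needed for the effect. In this assay compound 2 gave only a limit, > 26000 nM, so its true value is not known. Compound 1 `CCOC(=O)CCCCCOc1cccc(CN(C(=O)c2ccccc2)C(C)C)c1` likewise reached only a limit in this assay, > 26000 nM. Compound 3 `CCOC(=O)CCCCCOc1cccc(CN(C(=O)c2ccc(-c3ccco3)cc2)C(C)C)c1` also gave only a limit, > 26000 nM. Because (the limit of > 26000 nM in this assay, at which 3 of the 3 values shown sit), none of the steps among these three can be read: a step that the two limits leave unreadable from compound 1 to compound 2, a step that the two limits leave unreadable from compound 1 to compound 3 and a step that the two limits leave unreadable from compound 2 to compound 3 all stay hidden behind the limits.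

Compound 4 `CCOC(=O)CCCCCOc1cccc(CN(C(=O)c2ccc(-c3cccc(Oc4ccccc4)c3)cc2)C(C)C)c1` differs from compound 2 in a single place: phenoxy in place of phenyl on an aromatic carbon. The measured steps that bear on this change are the three just named, and each of them has no readable size. There is thus nothing in these data that points to a move in either direction for compound 4. The expected step is a step that the limit leaves unreadable from compound 2 to compound 4, none beyond the scatter. Compound 4 is therefore estimated at 40000 nM, with a range from 20000 nM to 100000 nM, and most likely this assay will again report only a limit for compound 4.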

Compound 4, half-maximal effective concentration: > 26000 nM
Compound 4: only a limit was reported; the forecaster's own chance of this, stated with the estimate: 85%; the middle value is on the limit's open side.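

For the compounds shown here, compound 4, like compound 2, gave only a limit, so the step between these two compounds cannot be read, and no new step emerges: the limit of > 26000 nM in this assay, at which 4 of the 4 values shown sit.

In this assay the compounds shown leave open what the true values are and whether phenoxy in place of phenyl changes anything at all.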